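Compound 4 and the ester-to-amide change

A few compounds are considered here, and "the series" means these few. Any claim that something is new, unique, unknown or untested is made for them only; others in the source may bear on it.

Of the compounds shown here, three sharing one core have been measured in an ADME assay on CEM-SS cells (Homo sapiens) for cytotoxicity, read by XTT assay, with a stated time of 6 days; a lower number here means that less compound is tolerated, a higher number that more compound is tolerated. Compound 1 `CCCC(=O)OCSc1ccccc1C(=O)NCCCC(N)=O` gives 56.6 uM, compound 2 `CCCC(=O)OCSc1ccccc1C(=O)NCCCCCNC(C)=O` gives 9.2 uM, and compound 3 `CCCC(=O)OCSc1ccccc1C(=O)NCC(=O)OC` gives 27.3 uM. Compound 3 thus stands second highest of the three: there is a 2.1-fold lower number from compound 1 to compound 3 (0.32 log units; beyond the scatter) and a 3.0-fold higher number from compound 2 to compound 3 (0.47 log units; beyond the scatter), with a 6.2-fold lower number from compound 1 to compound 2 (0.79 log units; beyond the scatter) spanning the whole set. Compound 4 `CCCC(=O)OCSc1ccccc1C(=O)NCC(=O)NC(C)(C)C` differs from compound 3 by a change the measured steps only approach indirectly: (tert-butyl)amino in place of methoxy on a carbonyl carbon. Among the compounds with values here, no measured step alters the carbonyl carbon itself; the steps between compound 1, compound 2 and compound 3 all concern the chain on the amide-type nitrogen, and they are modest in size, pointing in no single direction for an added amide-type group. Compound 4 is therefore expected to stay close to compound 3, with a 1.1-fold higher number from compound 3 to compound 4 (0.04 log units; within the scatter) as the expected step, likely within the scatter. The estimate for compound 4 in this assay is 30 uM, ranging from 12 uM to 70 uM.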

Compound 4, half-maximal toxic concentration: 46.8 uM
For compound 4 the middle estimate is 1.6-fold (0.19 log units) below the measured one; low and high end bracket the measured number.
By their numbers in this assay, from the lowest: compound 2; then compounds 3, 4 and 1 (each within the scatter of the next, the first and the last beyond it).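

In this assay, within the data shown here, the first measured exchange on this carbonyl carbon, (tert-butyl)amino in place of methoxy, stays within the scatter (a 1.7-fold higher number from compound 3 to compound 4 (0.23 log units; within the scatter)). Among these compounds, the (tert-butyl)carbamoyl chain also stays within the scatter of the 2-carbamoylethyl chain (a 1.2-fold lower number from compound 1 to compound 4 (0.08 log units; within the scatter)) but not of the 4-acetamidobutyl chain (a 5.1-fold higher number from compound 2 to compound 4 (0.71 log units; beyond the scatter)), which leaves compound 2 as the only compound beyond the scatter of all the others. Nothing measured here gives a reason for any of these steps.

From the compounds shown here alone, whether the tert-butyl group or the amide hydrogen matters more at this carbonyl carbon stays open, and a plain amino or a methylamino group in the same place could separate the two. Going by these compounds, a carboxylic acid in place of the methyl ester, or the same exchange on a longer chain, also remains unknown.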